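A few compounds are considered here, and "the series" means these few. Any claim that something is new, unique, unknown or untested is made for them only; others in the source may bear on it.

Compound 1 `C[C@H](NC(=O)c1ncccn1)c1ccc(NC(=O)N2CC(c3cccnc3)C2)cc1` gives 28.9 mL.min-1.g-1 in an ADME assay on microsomes from liver (Mus musculus) for pharmacokinetics, read by LC-MS, using NADPH, with stated times of 5 min, 15 min and 30 min, tested at 10 uM; a lower number here means slower removal, a higher number faster removal of the compound. Compound 2 `C[C@H](NC(=O)C1CCOCC1)c1ccc(NC(=O)N2CC(c3cccnc3)C2)cc1` differs from it in one place, (oxan-4-yl in place of pyrimidin-2-yl on a carbonyl carbon), and in this assay compound 2 gives 58 mL.min-1.g-1. That change made a 2.0-fold higher number from compound 1 to compound 2 (0.30 log units; within the scatter). Compound 3 `C[C@H](NC(=O)c1ncccn1)c1ccc(NC(=O)N2CC(c3ccc(N)nc3)C2)cc1` differs from compound 1 at another place, (amino in place of hydrogen on an aromatic carbon). In this assay compound 3 reaches only a limit of the assay and not a number, < 25 mL.min-1.g-1, which is the limit of < 25 mL.min-1.g-1 in this assay, at which 1 of the 3 values shown sits. The step so reads an at least 1.1-fold lower number from compound 1 to compound 3 (0.06 log units; that floor lies within the scatter).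

Compound 4 `C[C@H](NC(=O)C1CCOCC1)c1ccc(NC(=O)N2CC(c3ccc(N)nc3)C2)cc1` has not yet been measured in this assay. It differs from compound 3 by oxan-4-yl in place of pyrimidin-2-yl on a carbonyl carbon, the same change that was made from compound 1 to compound 2, here on the core of compound 3, which differs from the core of compound 1 by amino in place of hydrogen on an aromatic carbon. The place of the change is the same word for word in both cases, so this is the same change. The step from compound 3 to compound 4 is expected to be an at least 1.6-fold higher number from compound 3 to compound 4 (0.20 log units; that floor lies within the scatter), resting on the earlier step of a 2.0-fold higher number from compound 1 to compound 2 (0.30 log units; within the scatter). Compound 4 is therefore expected to give about 40 mL.min-1.g-1, between 20 mL.min-1.g-1 and 80 mL.min-1.g-1.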

Compound 4, intrinsic clearance in microsomes: < 25 mL.min-1.g-1
Compound 4: only a limit was reported; the forecaster's own chance of this, stated with the estimate: 20%; middle value at least 1.6-fold (0.20 log units) away from the limit.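

In this assay compound 4 gives < 25 mL.min-1.g-1, which is a limit of the assay and not a number, and compound 3 also stands at a limit, so the step for the oxan-4-yl change on the amino-bearing core cannot be read: the limit of < 25 mL.min-1.g-1 in this assay, at which 2 of the 4 values shown sit. The amino change can be read on the oxan-4-yl side, where it gives an at least 2.3-fold lower number from compound 2 to compound 4 (0.36 log units; beyond the scatter). This shows that the amino group goes with a lower number on both cores, at least beyond the scatter on the second, but it does not show whether the oxan-4-yl change carries over from the core of compound 1 to the core of compound 3, or whether the amino change has the same size on the two cores: the same change on two cores in this assay, an at least 1.1-fold lower number (0.06 log units; that floor lies within the scatter) from compound 1 to compound 3 and an at least 2.3-fold lower number (0.36 log units; beyond the scatter) from compound 2 to compound 4; the limit leaves it open whether they differ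

From the compounds shown here alone, the true values behind the limits for compound 3 and compound 4 remain open, and with them the size of the oxan-4-yl change on this core. Going by these compounds, it is also open whether a hydroxyl or methoxy group in place of the amino group, or a longer chain in place of oxan-4-yl on the carbonyl carbon, would follow the same course.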